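From (Pyridin-2-yl)methyl to Pyridin-2-yl on an Amide Nitrogen

The source may report more compounds than this note shows. Statements on the series, on what has been measured and on what is new or still open speak of the compounds shown alone.

Of the compounds shown here, three have been measured in an ADME assay on MRC5 cells (Homo sapiens) for inhibition, with a stated time of 72 h; on this read-out higher numbers stand for an effect only at larger amounts of compound and lower numbers for an effect already at smaller amounts. Compound 1 `CO[C@H]1CC[C@H](NC(=O)c2n[nH]cc2NC(=O)c2c(C)nc3ccccn23)CC1` gives 34000 nM in this assay, while compound 3 `CO[C@H]1CC[C@H](NC(=O)c2n[nH]cc2NC(=O)c2ccc(-c3ccccc3)o2)CC1` gives 100 nM. Compound 2 `COc1cccc(OC)c1C(=O)Nc1c[nH]nc1C(=O)NCc1ccccn1` sits at the limit of > 50000 nM in this assay, at which 1 of the 3 values shown sits, so its reading of > 50000 nM is a limit of the assay rather than a number.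

Compound 4 `COc1cccc(OC)c1C(=O)Nc1c[nH]nc1C(=O)Nc1ccccn1` differs from compound 2 in a single place: pyridin-2-yl in place of (pyridin-2-yl)methyl on an amide-type nitrogen. Among the measured compounds shown here, no measured pair shows this change, so the expectation rests on compound 2 alone. In this assay the step is expected to be none beyond the scatter, with compound 4 most likely again reported only as a limit. Compound 4 is therefore estimated at 50000 nM, within 20000 nM to 100000 nM. The expected step is a number no higher from compound 2 to compound 4 (the limit leaves the size open).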

Compound 4, half-maximal effective concentration: > 50000 nM
Compound 4 was reported as a limit; the forecaster's own chance of this, stated with the estimate: 70%; the middle value sits exactly at the limit.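

No step can be read between compound 2 and compound 4, as both readings are limits of the assay: the limit of > 50000 nM in this assay, at which 2 of the 4 values shown sit. The compounds shown leave open whether pyridin-2-yl and (pyridin-2-yl)methyl on the amide-type nitrogen differ at all in this assay.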